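The source may report more compounds than this note shows. Statements on the series, on what has been measured and on what is new or still open speak of the compounds shown alone.

Measured compounds:
compound 1, `COC(=O)C1=C(C)NC(=O)NC1c1cccs1`: 6%
compound 2, `COC(=O)C1=C(C)N(C)C(=O)NC1c1ccco1`: 45%
compound 3, `COC(=O)C1=C(C)N(C)C(=O)NC1c1ccoc1`: 15%

In an assay on membranes from CHO cells for displacement of a labelled ligand from adenosine receptor A1 (Homo sapiens), read by scintillation counting, with a stated time of 60 min, tested at 1 uM (a higher number here means more inhibition at the concentration tested (going by the name of the read-out), a lower number less inhibition), compound 3 stands second highest of the three numbers. Its nearest neighbour is compound 1, whose value lies within the scatter; its furthest is compound 2, which lies beyond the scatter above it, as the step of a number 30 percentage points lower from compound 2 to compound 3 (beyond the scatter) shows. Compound 4, `COC(=O)C1=C(C)N(C)C(=O)NC1c1cccs1`, differs from compound 3 by thiophen-2-yl in place of furan-3-yl on a saturated ring carbon. Within the data shown here, no measured step swaps the oxygen-containing ring for the sulfur-containing one on this core; the only measured step, a number 30 percentage points lower from compound 2 to compound 3 (beyond the scatter), concerns which ring carbon attaches, and the number is higher with the 2-attached ring. Compound 1 carries the same thiophen-2-yl ring without the ring-nitrogen methyl and gives 6%. A rise is therefore expected but uncertain: the estimated step for compound 4 is a number 15 percentage points higher from compound 3 to compound 4 (beyond the scatter), giving 30% in this assay, within 5% to 55%.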

Compound 4, a percentage reported as inhibition, at one concentration (the size of the read-out at that concentration, not a potency): 30%
The estimate for compound 4 equals the measured number at the digits printed; the measured number falls inside the stated range.
By their numbers in this assay, from the lowest: compounds 1 and 3 (each within the scatter of the next); then compound 4; then compound 2.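

In this assay the ring on this saturated ring carbon matters in both directions: thiophen-2-yl gives a number 15 percentage points higher from compound 3 to compound 4 (beyond the scatter) when it replaces furan-3-yl, but a number 15 percentage points lower from compound 2 to compound 4 (beyond the scatter) when it replaces furan-2-yl. Methyl in place of hydrogen on the amide-type nitrogen, seen here as a single change for the first time, gives a number 24 percentage points higher from compound 1 to compound 4 (beyond the scatter) with the thiophen-2-yl ring kept. Nothing available explains these shifts. As far as these compounds go, whether that methyl acts the same way with either furan ring stays open. So does the outcome with a phenyl ring on this carbon, or with ethyl on that nitrogen.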